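The compounds below may be only part of what the source reports. "The series", "measured", "known", "first", "only" and "open" are said of these compounds alone.

Compound 1 `COc1ccc(/C=C/c2ccc3ccccc3c2)cc1` gives > 5000 nM in a functional assay on P388 cells (Mus musculus) for inhibition (a lower number here means a stronger inhibitor, a higher number a weaker inhibitor), which is a limit of the assay. Compound 2 `CN(C)c1ccc(/C=C/c2ccc3ccccc3c2)cc1` gives 3660 nM in this assay. Compound 3 `COc1c([N+](=O)[O-])cc(/C=C/c2ccc3ccccc3c2)cc1[N+](=O)[O-]` gives > 5000 nM in this assay, again a limit of the assay. Compound 4 `CN(C)c1c([N+](=O)[O-])cc(/C=C/c2ccc3ccccc3c2)cc1[N+](=O)[O-]` has not yet been measured.

From compound 1 to compound 2 the change is dimethylamino in place of methoxy on an aromatic carbon. This gave an at least 1.3-fold lower number from compound 1 to compound 2 (0.13 log units; that floor lies within the scatter). The difference between the core of compound 1 and the core of compound 3 is not broken down here. Compound 4 carries the same kind of change on compound 3: dimethylamino in place of methoxy on an aromatic carbon. The surroundings differ in that the place is now ortho to two nitro groups. Since two of the three values sit at the limit of > 5000 nM in this assay, at which 2 of the 3 values shown sit, the starting point of compound 3 is itself only a limit. The step expected from compound 3 to compound 4 is a number no higher from compound 3 to compound 4 (the limit leaves the size open), resting on an at least 1.3-fold lower number from compound 1 to compound 2 (0.13 log units; that floor lies within the scatter) in compound 2, a step within the scatter. Compound 4 is therefore estimated at 5000 nM, expected between 1500 nM and 15000 nM.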

Compound 4, half-maximal inhibitory concentration: > 5000 nM
Compound 4 gave a limit, no number; the forecaster's own chance of this, stated with the estimate: 60%; the middle value sits exactly at the limit.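

Compound 3 and compound 4 both give only a limit of the assay in this assay, so no step between them can be read: the limit of > 5000 nM in this assay, at which 3 of the 4 values shown sit.

On these data alone, whether dimethylamino in place of methoxy alters inhibition when ortho to two nitro groups stays open.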